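Adding a group to the amine nitrogen of compound 2

This account rests on a few compounds, and the source may have more. Where it says the series, first, only, none or still open, it means among the compounds named here.

Measured in an ADME assay on FSCLL cells (Homo sapiens) for cytotoxicity, read by MTT assay, with a stated time of 24 h; on this read-out higher numbers stand for lower toxicity in this test and lower numbers for higher toxicity in this test:
- compound 1 `CC[C@H](N)C(=O)N[C@@H](CC(C)C)B(O)O` gives 1500 nM
- compound 2 `CC(C)C[C@H](NC(=O)[C@@H](N)[C@@H](C)O)B(O)O` gives 2500 nM
- compound 3 `CC(C)C[C@H](NC(=O)CN)B(O)O` gives 670 nM

Compound 2 carries the highest of the three numbers, but it cannot be separated from compound 1: a 1.7-fold higher number from compound 1 to compound 2 (0.22 log units; within the scatter). Compound 3 lies lower, with a 3.7-fold lower number from compound 2 to compound 3 (0.57 log units; beyond the scatter) and a 2.2-fold lower number from compound 1 to compound 3 (0.35 log units; beyond the scatter).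

Compound 4 `CC(C)C[C@H](NC(=O)[C@@H](NC(=O)c1cnccn1)[C@@H](C)O)B(O)O` differs from compound 2 by (pyrazin-2-yl)carbonyl in place of hydrogen on an amine nitrogen. In words, it has (pyrazin-2-yl)carbonyl in place of hydrogen on an amine nitrogen. Within the data shown here, all three measured steps changed a saturated chain carbon, and no measured compound carries anything on that amine nitrogen. They therefore give no direct measure of this change, and their modest sizes set no limit on it. A lower number in this assay is expected, but this is a judgment and the range stays wide. The expected step is a 13-fold lower number from compound 2 to compound 4 (1.10 log units; beyond the scatter). For compound 4 the estimated value is 200 nM, with an expected range from 20 nM to 1500 nM.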

Compound 4, half-maximal cytotoxic concentration: 100 nM
Compound 4: the middle estimate sits 2.0-fold (0.30 log units) above what was measured; the range from low to high includes it.
By their numbers in this assay, from the lowest: compound 4; then compound 3; then compounds 1 and 2 (each within the scatter of the next).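

In this assay, the amine nitrogen of compound 2 proves a far more sensitive place than the saturated chain carbon: (pyrazin-2-yl)carbonyl in place of hydrogen gives a 25-fold lower number from compound 2 to compound 4 (1.40 log units; beyond the scatter), and on this read-out that means higher toxicity in this test. The largest earlier step, a 3.7-fold lower number from compound 2 to compound 3 (0.57 log units; beyond the scatter), came from a change on the chain carbon and is clearly smaller, so substitution on this nitrogen opens a range the compounds with a free amine did not reach. Nothing measured here bears on why the number falls.

On these data alone, it remains open whether the step needs the six-membered aromatic ring or whether the carbonyl alone suffices, which an acetyl or a benzoyl on the same nitrogen would separate. Also open, as far as these compounds go, is whether (pyrazin-2-yl)carbonyl would act alike on the amine nitrogen of compound 1 or compound 3.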